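The source may hold more compounds than are shown below. What is called first, only, known or untested is meant among the compounds shown, and "the series" means these compounds.

Compound 2 `CNC(=O)[C@@H](c1ccccc1)N1CCn2c(C3CC3)nc(Cl)c2[C@@H]1CCc1cccc(C(F)(F)F)c1` gives 91 nM in a functional assay on CHO cells for antagonist activity at Orexin/Hypocretin receptor type 1 (Homo sapiens), read by FLIPR and calcium flux (on this read-out higher numbers stand for weaker inhibition and lower numbers for stronger inhibition), the higher of the two numbers; compound 1 `CNC(=O)[C@@H](c1ccccc1)N1CCn2c(C3CC3)nc(Cl)c2[C@@H]1CCc1ccc(C(F)(F)F)cc1` gives 30 nM. Among the compounds with values here, the one measured step that bears on the next change is a 3.0-fold higher number from compound 1 to compound 2 (0.48 log units; beyond the scatter). Compound 3 `CNC(=O)[C@@H](c1ccccc1)N1CCn2c(C3CC3)nc(Cl)c2[C@@H]1CCc1ccc(C(F)(F)F)c(F)c1` differs from compound 2 by 3-fluoro-4-(trifluoromethyl)phenyl in place of 3-(trifluoromethyl)phenyl on a saturated chain carbon, two bonds along the chain from a saturated ring carbon, which brings the trifluoromethyl group back to the position it holds in compound 1 while adding a fluorine. Compound 3 is therefore expected to recover most of that measured step, estimated as a 2.6-fold lower number from compound 2 to compound 3 (0.41 log units; beyond the scatter). The expected value for compound 3 is 35 nM, with a range from 12 nM to 100 nM.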

Compound 3, half-maximal inhibitory concentration: 53 nM
For compound 3 the middle estimate is 1.5-fold (0.18 log units) below the measured one; the measured number falls inside the stated range.
By their numbers in this assay, from the lowest: compounds 1, 3 and 2 (each within the scatter of the next, the first and the last beyond it).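

Adding fluoro on an aromatic carbon of compound 1 gives a 1.8-fold higher number from compound 1 to compound 3 (0.25 log units; within the scatter), so the trifluoromethyl-bearing ring accepts this extra fluorine without a change that the read-out can resolve. The other new step, a 1.7-fold lower number from compound 2 to compound 3 (0.23 log units; within the scatter), also stays inside the scatter, leaving compound 3 indistinguishable from both compound 1 and compound 2, although those two are separated by a step beyond it. No measured evidence explains these numbers. From the compounds shown here alone, it remains open how chloro or methoxy would read in place of this fluoro, and whether a nitrile could stand in for the trifluoromethyl group.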